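A few compounds are considered here, and "the series" means these few. Any claim that something is new, unique, unknown or untested is made for them only; others in the source may bear on it.

Compound 1 `COc1ccc(/C=C(/Sc2ccc(C)cc2)C(=O)c2ccc(Br)cc2)cc1` and compound 2 `CSc1ccc(/C=C(/Sc2ccc(C)cc2)C(=O)c2ccc(Br)cc2)cc1` share one core and differ by methoxy in place of methylsulfanyl on an aromatic carbon. In a functional assay on DU-145 cells (Homo sapiens) for inhibition, read by trypan blue exclusion, with a stated time of 96 h (on this read-out higher numbers stand for weaker inhibition of growth and lower numbers for stronger inhibition of growth), compound 1 gives 50000 nM, and compound 2 gives 50000 nM; the step reads no change at the digits printed from compound 2 to compound 1 (within the scatter). Compound 3 `CSc1ccc(/C=C(\C(=O)c2ccc(Br)cc2)S(=O)(=O)c2ccc(C)cc2)cc1` stands on a different core; in this assay compound 3 gives 1000 nM, the lowest of the three numbers, and its distance to compound 1 and to compound 2 lies beyond the scatter. The difference between the core of compound 3 and that of compound 2 is not broken down here. Compound 4 `COc1ccc(/C=C(\C(=O)c2ccc(Br)cc2)S(=O)(=O)c2ccc(C)cc2)cc1` has not yet been measured; it differs from compound 3 by methoxy in place of methylsulfanyl on an aromatic carbon, the same change as between compound 2 and compound 1, with the place described in the same words. Given that this change produced no change at the digits printed from compound 2 to compound 1 (within the scatter), a like outcome is expected: no change at the digits printed from compound 3 to compound 4 (within the scatter). Compound 4 is therefore estimated at 1000 nM, between 400 nM and 3000 nM.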

Compound 4, concentration for 50% growth inhibition: 1000 nM
Compound 4: the middle estimate sits on the measured number at the digits printed; the range from low to high includes it.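

In this assay the change from 4-(methylsulfanyl)phenyl to 4-methoxyphenyl gives no change at the digits printed from compound 3 to compound 4 (within the scatter), and it reads the same on both cores: the same change on two cores in this assay, no change at the digits printed (within the scatter) from compound 2 to compound 1 and no change at the digits printed (within the scatter) from compound 3 to compound 4, 1.0-fold (0.00 log units) apart, within the scatter of two such steps. For these two pairs, the change therefore carries from one core to the other without a step beyond the scatter. Among these compounds, this rests on only two pairs in one cell assay, so it does not establish the same outcome on any further core, and it gives no reason for the outcome.

From the compounds shown here alone, whether an amine, a carboxylic acid or a longer alkoxy chain on that aromatic carbon would give a similar number remains open. Going by these compounds, the effect of this change in other cell lines also remains open.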